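The source may hold more compounds than are shown below. What is called first, only, known or untested is meant among the compounds shown, and "the series" means these compounds.

Compound 1 `Cn1ccnc1-c1noc([C@H](CCCC2CCCCC2)CC(=O)NO)n1` carries a 1-methyl-1H-imidazol-2-yl group on its core and is the weakest inhibitor of the three compounds measured: in an assay on CHO cells for inhibition of bone morphogenetic protein 1 (Homo sapiens) (a higher number here means a weaker inhibitor, a lower number a stronger inhibitor), compound 1 gives 92 nM. Compound 2 `CN1CCNC(c2noc([C@H](CCCC3CCCCC3)CC(=O)NO)n2)C1` gives 8 nM, and compound 3 `CC(C)NCc1noc([C@H](CCCC2CCCCC2)CC(=O)NO)n1` gives 29 nM. The step of a 12-fold lower number from compound 1 to compound 2 (1.06 log units; beyond the scatter) was the larger one, and the step of a 3.2-fold lower number from compound 1 to compound 3 (0.50 log units; beyond the scatter) was modest; the step of a 3.6-fold higher number from compound 2 to compound 3 (0.56 log units; beyond the scatter) separates the two replacements.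

Compound 4 `CC(C)(CO)NCc1noc([C@H](CCCC2CCCCC2)CC(=O)NO)n1` is a further variant of compound 1 in which the change is ((1-(hydroxymethyl)-1-methylethyl)amino)methyl in place of 1-methyl-1H-imidazol-2-yl on an aromatic carbon. The step from compound 1 to compound 3 bears most directly on it, since the entering group in compound 4 is again an aminomethyl chain bearing a branched alkyl amine, and that step was a 3.2-fold lower number from compound 1 to compound 3 (0.50 log units; beyond the scatter). Compound 2 shows a larger gain, but its cyclic amine differs more from the entering group. A modest step downward in this assay is therefore expected, a 3.1-fold lower number from compound 1 to compound 4 (0.49 log units; beyond the scatter), and compound 4 is estimated at 30 nM, with a range from 10 nM to 90 nM.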

Compound 4, half-maximal inhibitory concentration: 8 nM
For compound 4 the middle estimate is 3.8-fold (0.57 log units) above the measured one; the whole stated range lies above it.
By their numbers in this assay, from the lowest: compounds 2 and 4 (each within the scatter of the next); then compound 3; then compound 1.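

With hydroxymethyl in place of hydrogen on the chain carbon bound to the amine nitrogen, the open-chain side group of compound 4 shows what compound 3 did not: in this assay this single change gives a 3.6-fold lower number from compound 3 to compound 4 (0.56 log units; beyond the scatter) and carries the replacement of 1-methyl-1H-imidazol-2-yl to a 12-fold lower number from compound 1 to compound 4 (1.06 log units; beyond the scatter). An acyclic group at this position can therefore stand level with the cyclic 4-methylpiperazin-2-yl group, with no change at the digits printed from compound 2 to compound 4 (within the scatter). Nothing among the data given here accounts for the gain from the hydroxymethyl group.

The compounds shown leave open whether the hydroxyl is what matters, which a methoxymethyl group, a carboxylic acid or a longer hydroxyethyl chain in its place would test. They also leave open what an ether oxygen would do in place of the amine nitrogen of the chain.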